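Sulfonyl aryl swaps on the shared core

This account rests on a few compounds, and the source may have more. Where it says the series, first, only, none or still open, it means among the compounds named here.

The series shares one core, carried in compound 3 `Cc1cccc(S(=O)(=O)Nc2ccc(-c3nc4ccccc4o3)cc2)c1`, compound 1 `O=S(=O)(Nc1ccc(-c2nc3ccccc3o2)cc1)c1cccs1` and compound 2 `O=S(=O)(Nc1ccc(-c2nc3ccccc3o2)cc1)c1ccccc1O`; the three differ only in the aryl group on the sulfonyl sulfur. In an assay on isolated protein for inhibition of malate dehydrogenase, mitochondrial (Sus scrofa), with stated times of 45 min and 30 min (a lower number here means a stronger inhibitor, a higher number a weaker inhibitor), compound 3 gives > 63000 nM, which is a limit of the assay and not a number. Compound 1 likewise gives > 63000 nM, a limit. Compound 2 gives > 63000 nM, again a limit. Compound 3 therefore stands nowhere that can be ranked, since all three values sit at the same limit (the limit of > 63000 nM in this assay, at which 3 of the 3 values shown sit). The steps among them are a step that the two limits leave unreadable from compound 1 to compound 2, a step that the two limits leave unreadable from compound 1 to compound 3 and a step that the two limits leave unreadable from compound 2 to compound 3, so no size or direction is readable from any of them.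

Compound 4 `O=S(=O)(Nc1ccc(-c2nc3ccccc3o2)cc1)c1ccccc1F` is not yet measured. It differs from compound 3 by 2-fluorophenyl in place of 3-methylphenyl on a sulfonyl sulfur. Every measured step bears on it only in the sense that three exchanges of the sulfonyl aryl group each left the compound at the limit, setting neither size nor direction. The expected step that the limit leaves unreadable from compound 3 to compound 4 is none beyond the scatter. Compound 4 is expected to be reported at the limit once more, estimated at 100000 nM, between 30000 nM and 400000 nM.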

Compound 4, half-maximal inhibitory concentration: > 63000 nM
Compound 4: a limit, no number (the forecaster's own chance of this, stated with the estimate: 85%); the middle value lies beyond the limit too.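

The steps linking compound 4 with compound 1, compound 2 and compound 3 cannot be read, and all four compounds rest at a single limit: the limit of > 63000 nM in this assay, at which 4 of the 4 values shown sit.

The compounds shown leave open whether any aryl group on the sulfonyl sulfur of the shared core gives a measurable value in this assay, and how far such groups would differ.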